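From Methylpiperazine to Methylpiperidine on the Chain End

The source may report more compounds than this note shows. Statements on the series, on what has been measured and on what is new or still open speak of the compounds shown alone.

Three compounds share one core and differ only in the saturated ring that sits on a saturated chain carbon, three bonds along the chain from an oxygen on an aromatic ring. In an assay on cerebellum for displacement of a labelled ligand from histamine H1 receptor (Cavia porcellus), read by scintillation counting, with a stated time of 60 min (on this read-out higher numbers stand for weaker inhibition and lower numbers for stronger inhibition), compound 1 `CN1CCc2ccc(OCCCN3CCCCC3)cc2C1=O` gives 23 nM. Compound 2 `CN1CCc2ccc(OCCCN3CCCC3)cc2C1=O` gives 39 nM in this assay, and compound 3 `CN1CCN(CCCOc2ccc3c(c2)C(=O)N(C)CC3)CC1` gives 706 nM. Compound 3 therefore shows the highest number of the three: the step of a 31-fold higher number from compound 1 to compound 3 (1.49 log units; beyond the scatter) and the step of an 18-fold higher number from compound 2 to compound 3 (1.26 log units; beyond the scatter) are both large, whereas a 1.7-fold higher number from compound 1 to compound 2 (0.23 log units; within the scatter) stays within the scatter.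

Compound 4 `CC1CCCCN1CCCOc1ccc2c(c1)C(=O)N(C)CC2` has not yet been measured. Its change from compound 3 is 2-methylpiperidin-1-yl in place of 4-methylpiperazin-1-yl on a saturated chain carbon, three bonds along the chain from an oxygen on an aromatic ring. This largely undoes the change that gave the large step from compound 1 to compound 3, with a methyl now carried on the entering ring. For the measured compounds named here, because compound 3 stands so far above compound 1 after a 31-fold higher number from compound 1 to compound 3 (1.49 log units; beyond the scatter), the number is expected to fall sharply once more; the methyl on the ring has no measured precedent here. The expected step is a 20-fold lower number from compound 3 to compound 4 (1.30 log units; beyond the scatter). Compound 4 is estimated at 35 nM, with a range from 10 nM to 120 nM.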

Compound 4, inhibition constant: 165 nM
Compound 4: the middle estimate sits 4.7-fold (0.67 log units) below what was measured; measured number above the stated range.
By their numbers in this assay, from the lowest: compounds 1 and 2 (each within the scatter of the next); then compound 4; then compound 3.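

Replacing 4-methylpiperazin-1-yl with 2-methylpiperidin-1-yl at this place on the chain recovers only part of the ground lost to the methylpiperazine in this assay (a 4.3-fold lower number from compound 3 to compound 4 (0.63 log units; beyond the scatter)). The earlier compounds shown here varied only the saturated ring itself, so they could not show that a single methyl on a saturated ring carbon also changes the result: adding it to the piperidine ring weakens inhibition (a 7.2-fold higher number from compound 1 to compound 4 (0.86 log units; beyond the scatter)), and compound 4 also falls short of the smaller pyrrolidine compound (a 4.2-fold higher number from compound 2 to compound 4 (0.63 log units; beyond the scatter)). Nothing measured here explains why this methyl weakens inhibition or why the methylpiperazine weakens it further.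

The compounds shown leave open whether the loss follows the methyl wherever it sits on the ring, a question that 3-methylpiperidin-1-yl and 4-methylpiperidin-1-yl would address. They also leave open how much of the large loss in compound 3 goes with the second ring nitrogen and how much with its methyl, which 4-methylpiperidin-1-yl and piperazin-1-yl, with no methyl on the ring, could begin to separate.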